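A Thiazolidinone Series: Swapping the Ring Substituent Again

The source may report more compounds than this note shows. Statements on the series, on what has been measured and on what is new or still open speak of the compounds shown alone.

Measured so far:
- Compound 1, `O=C(CN1C(=O)c2ccccc2C1=O)NN1C(=O)CSC1c1ccccc1O` — in a physicochemical assay for lipophilicity, in phosphate buffer, measured as octanol-water partition, with a stated time of 24 h (on this read-out lower numbers stand for lower lipophilicity and higher numbers for higher lipophilicity), compound 1 gives 1.46
- Compound 2, `O=C(CN1C(=O)c2ccccc2C1=O)NN1C(=O)CSC1/C=C/c1ccccc1` — in this assay compound 2 gives 3.65

Among the measured compounds shown here, compound 2 holds the higher of the two numbers; the only other measured compound, compound 1, lies below it by a number 2.19 log units higher from compound 1 to compound 2 (beyond the scatter), a step well beyond the scatter. Compound 3, `O=C(CN1C(=O)c2ccccc2C1=O)NN1C(=O)CSC1c1c[nH]c2ccccc12`, has not yet been measured. Its change from compound 2 is 1H-indol-3-yl in place of 2-phenylethenyl on a saturated ring carbon. For the measured compounds named here, the one measured step bears on this only loosely: it shows that swapping the group on that saturated ring carbon can move the partition coefficient a great deal, as a number 2.19 log units higher from compound 1 to compound 2 (beyond the scatter) did, and that the group carrying a hydrogen-bond donor sat at the lower end. The incoming group here also brings one hydrogen-bond donor, while the departing group brings none. A downward step of moderate size is therefore expected, a number 0.85 log units lower from compound 2 to compound 3 (beyond the scatter). For compound 3 the estimate in this assay is 2.8, with a likely range from 2.2 to 3.4.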

Compound 3, partition coefficient: 1.59
Compound 3: middle estimate off by 1.21 log units, on the high side; measured number below the stated range.
By their numbers in this assay, from the lowest: compounds 1 and 3 (each within the scatter of the next); then compound 2.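

In this assay, a large fall at this saturated ring carbon turns out not to be specific to 2-hydroxyphenyl, since replacing 2-phenylethenyl with 1H-indol-3-yl also produces one (a number 2.06 log units lower from compound 2 to compound 3 (beyond the scatter)). The two groups that carry a hydrogen-bond donor differ in their ring systems, yet they cannot be told apart on this read-out (a number 0.13 log units higher from compound 1 to compound 3 (within the scatter)), while 2-phenylethenyl, which carries no donor, stands clear of both. This fits a link between the donor and the lower numbers across all three compounds, with none going against it, but nothing measured here gives the reason for the pattern.

On these data alone, whether the donor itself matters remains open, as the groups also differ in other ways; 2-methoxyphenyl in place of 2-hydroxyphenyl, or 1-methylindol-3-yl in place of 1H-indol-3-yl, would test this by changing little except the donor. As far as these compounds go, how the number would respond to an amine or a carboxylic acid on this carbon also remains unknown, as does the effect of a simple unsubstituted phenyl.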